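A Carbamate Tail Swap on an ATM Inhibitor Scaffold

A few compounds are considered here, and "the series" means these few. Any claim that something is new, unique, unknown or untested is made for them only; others in the source may bear on it.

Of the compounds shown here, two of a shared core have been measured in an assay on MCF7 cells for inhibition of Serine-protein kinase ATM (Homo sapiens), read by immunofluorescence, with a stated time of 1 h; a higher number here means a weaker inhibitor, a lower number a stronger inhibitor. Compound 1 `COc1cc2ncnc(-n3nc(-c4ccccn4)nc3N)c2cc1OCCCCNC(=O)OC(C)(C)C` gives 800 nM. Compound 2 `COc1cc2ncnc(-n3nc(-c4ccccn4)nc3N)c2cc1OCCCNC(=O)OCC(F)(F)F` gives 1200 nM. Compound 2 therefore holds the higher of the two numbers, yet the step of a 1.5-fold higher number from compound 1 to compound 2 (0.18 log units; within the scatter) is within the scatter, so the two compounds cannot be told apart on these data.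

Compound 3 `COc1cc2ncnc(-n3nc(-c4ccccn4)nc3N)c2cc1OCCCNC(=O)OCC(C)(C)C` differs from compound 2 in one place: tert-butyl in place of trifluoromethyl on a saturated chain carbon bound to an oxygen next to a carbonyl group. Among the measured compounds shown here, the only measured step that bears on this is the one from compound 1 to compound 2, which exchanged a tert-butyl-bearing carbamate for a trifluoroethyl-bearing one while also shortening the chain, and that step stayed within the scatter. Compound 3 returns a tert-butyl group to the carbamate end while keeping the shorter chain of compound 2. The expectation is therefore a step of a 1.3-fold lower number from compound 2 to compound 3 (0.12 log units; within the scatter) that stays within the scatter, leaning if anything toward a lower number because compound 1 with its tert-butyl carbamate gave 800 nM. Compound 3 is estimated at 900 nM, with a range from 400 nM to 2000 nM.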

Compound 3, half-maximal inhibitory concentration: 1900 nM
Compound 3: middle estimate off by 2.1-fold (0.32 log units), on the low side, and the stated range covers the measured number.
By their numbers in this assay, from the lowest: compounds 1, 2 and 3 (each within the scatter of the next, the first and the last beyond it).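

In this assay, putting tert-butyl in place of trifluoromethyl on a saturated chain carbon bound to an oxygen next to a carbonyl group gives a 1.6-fold higher number from compound 2 to compound 3 (0.20 log units; within the scatter), so these two groups, with their equal count of heavy atoms, cannot be told apart at this place on the present data. Among the compounds shown here, the one step here that does pass the scatter is a 2.4-fold higher number from compound 1 to compound 3 (0.38 log units; beyond the scatter), a modest step, and since it alters the chain and the carbamate end together, it cannot be assigned to either part alone. No measurement beyond these numbers is available to explain either step.

The compounds shown leave open how much of that modest step belongs to the chain and how much to the group at the carbamate end, since no pair here changes the chain alone with the same carbamate end on both sides. Also open, going by these compounds, is how the number would respond to a longer chain, or to a plain amine or a carboxylic acid at the chain end in place of the carbamate.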